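This account rests on a few compounds, and the source may have more. Where it says the series, first, only, none or still open, it means among the compounds named here.

Working notes on the series, read in a functional assay on BGC-823 cells (Homo sapiens) for inhibition, read by sulforhodamine B assay, with a stated time of 3 days; on this read-out lower numbers stand for stronger inhibition and higher numbers for weaker inhibition. Three amides on the shared core have been measured: compound 1 (`COc1ccc(C(=O)Nc2ccc3c(c2)/C(=C/Nc2cccc(N4CCN(C)CC4)c2)C(=O)N3)cc1`) gives 3170 nM, compound 2 (`CN1CCN(c2cccc(N/C=C3\C(=O)Nc4ccc(NC(=O)c5cccc(F)c5)cc43)c2)CC1`) gives 8500 nM and compound 3 (`CN1CCN(c2cccc(N/C=C3\C(=O)Nc4ccc(NC(=O)c5c(Cl)cccc5Cl)cc43)c2)CC1`) gives 2240 nM. Compound 3 stands with compound 1 at the low end of these numbers, the two lying within the scatter of each other, while compound 2 stands clearly apart from both.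

Compound 4 (`CC(C)CC(=O)Nc1ccc2c(c1)/C(=C/Nc1cccc(N3CCN(C)CC3)c1)C(=O)N2`) is still unmeasured and carries isobutyl in place of 2,6-dichlorophenyl on a carbonyl carbon. The measured steps bearing on this change all fall at that same place: a 2.7-fold higher number from compound 1 to compound 2 (0.43 log units; beyond the scatter), a 1.4-fold lower number from compound 1 to compound 3 (0.15 log units; within the scatter) and a 3.8-fold lower number from compound 2 to compound 3 (0.58 log units; beyond the scatter). Going by the values given here, each exchanges one aromatic ring for another, and no measured compound has an open chain there, so these steps are only a loose guide. The upward direction rests on one observation: compound 2 at 8500 nM shows that leaving the 2,6-dichlorophenyl group can cost a modest step, while compound 1 at 3170 nM shows that it need not.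

The expected change in this assay is a modest one toward a higher number, a 2.2-fold higher number from compound 3 to compound 4 (0.35 log units; beyond the scatter). For compound 4 the estimated value is 5000 nM, with an expected range of 1800 nM to 14000 nM.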

Compound 4, half-maximal inhibitory concentration: 6080 nM
Compound 4: middle estimate off by 1.2-fold (0.08 log units), on the low side, and the stated range covers the measured number.
By their numbers in this assay, from the lowest: compounds 3, 1, 4 and 2 (each within the scatter of the next, the first and the last beyond it).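

The first open chain at this place shows that an aromatic ring on the carbonyl carbon is not needed for a number in the range of the earlier amides: in this assay, isobutyl in place of 2,6-dichlorophenyl gives a 2.7-fold higher number from compound 3 to compound 4 (0.43 log units; beyond the scatter). Going by these compounds alone, the chain is not separated from the other two aromatic amides, with a 1.4-fold lower number from compound 2 to compound 4 (0.15 log units; within the scatter) and a 1.9-fold higher number from compound 1 to compound 4 (0.28 log units; within the scatter), so among the open chain and the two other rings only the step from the 2,6-dichlorophenyl amide of compound 3 to isobutyl stands clear of the scatter. No measurement is at hand that accounts for this step.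

The compounds shown leave open how a longer chain, a cyclohexyl ring or a chain ending in an amine would read on this carbonyl carbon, since isobutyl is the only open chain here. They also leave open whether the step from compound 3 belongs to the ring itself or to its two chlorine atoms, a question that plain phenyl at the same place would bear on directly.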